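One Flipped Stereocentre, Starting From a Limit

This account rests on a few compounds, and the source may have more. Where it says the series, first, only, none or still open, it means among the compounds named here.

In a functional assay on MIA PaCa-2 cells (Homo sapiens) for inhibition, read by MTT assay, with a stated time of 3 days (a higher number here means a weaker inhibitor, a lower number a stronger inhibitor), compound 1 (`CCOC(=O)[C@@H]1CCC[C@@H](S(=O)(=O)c2ccc(S(=O)(=O)N(CC)CC)cc2)C1`) gives > 10000 nM as its result, and that is a limit of the assay, not a number. Compound 2 (`CCOC(=O)[C@@H]1CCCN(S(=O)(=O)c2cccc(S(=O)(=O)N(CC)CC)c2)C1`) gives > 10000 nM as its result, which is again a limit. The picture so far is therefore a single one (the limit of > 10000 nM in this assay, at which 2 of the 2 values shown sit). Among the measured compounds shown here, with no actual number on either compound, no measured step shows how far a structural change can move the result in this assay for these compounds.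

Compound 3 (`CCOC(=O)[C@@H]1CCC[C@H](S(=O)(=O)c2ccc(S(=O)(=O)N(CC)CC)cc2)C1`) is the close relative of compound 1 to consider next (the two compounds have the same atoms and bonds and differ only in configuration as drawn: 1 of 2 stereo elements differ; a stereocentre at a saturated ring carbon is drawn R in compound 1 and S in compound 3): a stereocentre at a saturated ring carbon is drawn R in compound 1 and S in compound 3. No atom or bond is gained or lost. The expectation in this assay is therefore a step in neither direction beyond the scatter, resting on compound 1 and its limit of > 10000 nM as the only close reference. The estimated step that the limit leaves unreadable from compound 1 to compound 3 is accordingly no real change. For compound 3 the estimate is 15000 nM with 7000 nM to 40000 nM as the expected range, and the assay will most likely report only a limit again.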

Compound 3, half-maximal inhibitory concentration: > 10000 nM
Compound 3 ended at the assay's limit; the forecaster's own chance of this, stated with the estimate: 85%; the middle value is on the limit's open side.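

In this assay compound 3 gives > 10000 nM, which is a limit of the assay and not a number. Compound 1 also sits at a limit, so the step between compound 1 and compound 3 cannot be read. With no actual number on any compound shown, it stays open whether the configuration at that saturated ring carbon can move the result at all.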